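Removing One Chloro from Compound 2: an Expected Outcome

The source may report more compounds than this note shows. Statements on the series, on what has been measured and on what is new or still open speak of the compounds shown alone.

Of the compounds shown here, three sharing a fused two-ring core have been tested in a functional assay on HT-29 cells (Homo sapiens) for cytotoxicity, read by sulforhodamine B assay, with a stated time of 48 h; a lower number here means a stronger inhibitor of growth, a higher number a weaker inhibitor of growth. Compound 1 `ClCc1cccc(Cn2cnc3c(Cl)ncnc32)c1` gives 3230 nM. Compound 3 `Nc1nc(Cl)c2ncn(Cc3cccc(CCl)c3)c2n1` gives 2510 nM, and the change a 1.3-fold lower number from compound 1 to compound 3 (0.11 log units; within the scatter) shows that adding an amino group left the number essentially where it was. Compound 2 `ClCc1ccc(Cn2cnc3nc(Cl)nc(Cl)c32)cc1` gives 3540 nM, the highest of the three numbers, yet its gaps to compound 1 and to compound 3 both fall within the scatter, so the three values cannot be told apart.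

Compound 4 `ClCc1ccc(Cn2cnc3ncnc(Cl)c32)cc1` differs from compound 2 in one place: hydrogen in place of chloro on an aromatic carbon. Among the compounds with values here, no measured pair shows exactly this change. Within the data shown here, the only single-point step available, from compound 1 to compound 3, involved a different group and stayed within the scatter, and compounds 1 and 2, which differ in more than one place including this chloro, give numbers that are also within the scatter of each other. On this basis a change of no more than the scatter is expected in this assay for compound 4, in either direction, so the expected step is a 1.0-fold lower number from compound 2 to compound 4 (0.02 log units; within the scatter). Compound 4 is therefore estimated at 3400 nM, with a range from 1500 nM to 8000 nM.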

Compound 4, concentration for 50% growth inhibition: 1230 nM
Compound 4: the middle estimate sits 2.8-fold (0.44 log units) above what was measured, outside the stated range (below it).
By their numbers in this assay, from the lowest: compound 4; then compounds 3, 1 and 2 (each within the scatter of the next).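

In this assay the chloro on the aromatic carbon between two ring nitrogen atoms turns out not to be needed for growth inhibition: with hydrogen in its place there is a modest but real change, a step of a 2.9-fold lower number from compound 2 to compound 4 (0.46 log units; beyond the scatter) that lies beyond the usual scatter. Within the data shown here, the only earlier step between compounds differing in one place, a 1.3-fold lower number from compound 1 to compound 3 (0.11 log units; within the scatter), put amino in place of hydrogen on an aromatic carbon and stayed within the scatter, so it gave no sign that a single swap on this core could move the number at all. Nothing among the data explains why losing this chloro goes with stronger growth inhibition.

Still open, on these data alone, is what other groups on this carbon would do in the setting of compound 4, for instance a fluoro, a methoxy or a methylamino group, and whether any of them would lower the number further or bring it back up. Also open, as far as these compounds go, is whether this step is of similar size when the rest of the molecule is arranged as in compound 1, which has hydrogen on this carbon.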